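Capping the phenol: from compound 3 to compound 4

The compounds below may be only part of what the source reports. "The series", "measured", "known", "first", "only" and "open" are said of these compounds alone.

Of the compounds shown here, three sharing one core have been measured so far. Compound 1 `COc1cccc(OC)c1OCCNC[C@H]1Oc2ccccc2O[C@@H]1C1CCCCC1` gives 813 nM in a functional assay for antagonist activity at Adrenergic receptor alpha-1 (Rattus norvegicus); on this read-out lower numbers stand for tighter binding and higher numbers for weaker binding. Compound 2 `CCc1ccc([C@H]2Oc3ccccc3O[C@@H]2CNCCOc2c(OC)cccc2OC)cc1` gives 15.1 nM. Compound 3 `COc1cccc(OC)c1OCCNC[C@H]1Oc2ccccc2O[C@@H]1c1ccc(O)cc1` gives 14.5 nM, the lowest of the three numbers, though compound 2 sits within the scatter of it, so no order between the two can be claimed; compound 1 lies far behind, as a 56-fold lower number from compound 1 to compound 3 (1.75 log units; beyond the scatter) shows.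

Compound 4 `COc1ccc([C@H]2Oc3ccccc3O[C@@H]2CNCCOc2c(OC)cccc2OC)cc1` is the next step. It differs from compound 3 in one place: methyl in place of hydrogen on an oxygen on an aromatic ring.

Two of the measured steps replace the cyclohexyl with an aromatic ring and are large, a 54-fold lower number from compound 1 to compound 2 (1.73 log units; beyond the scatter) and a 56-fold lower number from compound 1 to compound 3 (1.75 log units; beyond the scatter), but they concern a different part of the molecule. The step that bears directly on this change is a 1.0-fold lower number from compound 2 to compound 3 (0.02 log units; within the scatter): swapping a hydroxy for an ethyl on that aromatic ring changed nothing beyond the scatter. A methoxy sits between those two groups in kind, so no step beyond the scatter is expected in this assay, a 1.0-fold higher number from compound 3 to compound 4 (0.01 log units; within the scatter). Compound 4 is therefore expected to give about 15 nM, within a range from 5 nM to 45 nM.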

Compound 4, dissociation constant: 2.14 nM
Beside the measured number, compound 4's estimate is 7.0-fold (0.85 log units) above it, and the stated range ends above it.
By their numbers in this assay, from the lowest: compound 4; then compounds 3 and 2 (each within the scatter of the next); then compound 1.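

On this oxygen on an aromatic ring, one added methyl does what the swap of hydroxy for ethyl did not: in this assay it gives a step beyond the scatter (a 6.8-fold lower number from compound 3 to compound 4 (0.83 log units; beyond the scatter)). Methoxy also stands apart from ethyl (a 7.1-fold lower number from compound 2 to compound 4 (0.85 log units; beyond the scatter)), even though the values of compound 2 and compound 3 lie within the scatter of each other, so the group at this position does matter, and a 4-methoxyphenyl in place of cyclohexyl gives a large step (a 380-fold lower number from compound 1 to compound 4 (2.58 log units; beyond the scatter)). Nothing available here explains why the methoxy differs from both the hydroxy and the ethyl. Still open, as far as these compounds go, is whether a longer chain on this oxygen, such as ethoxy or propoxy, would lower the number further or raise it again. An amine or a fluorine in place of the methoxy is equally untested among the compounds shown.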